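Swapping the para methoxy for a nitrile: tolerance expected

A few compounds are considered here, and "the series" means these few. Any claim that something is new, unique, unknown or untested is made for them only; others in the source may bear on it.

Measured so far in an ADME assay on MT4 cells (Homo sapiens) for cytotoxicity, read by MTT assay, with a stated time of 4 days; a higher number here means that more compound is tolerated, a lower number that less compound is tolerated:
- compound 1 `Cc1cccc(NC(=O)CS(=O)(=O)c2nccc(Oc3c(C)cc(C#N)cc3C)n2)c1` gives 25700 nM
- compound 2 `COc1ccc(NC(=O)CS(=O)(=O)c2nccc(Oc3c(C)cc(C#N)cc3C)n2)cc1` gives 5110 nM
- compound 3 `Cc1cc(C#N)cc(C)c1Oc1ccnc(S(=O)(=O)CC(=O)Nc2cc(Cl)cc(Cl)c2)n1` gives 24000 nM

Among these three, compound 2 has the lowest number, so it is the least tolerated: the step of a 5.0-fold lower number from compound 1 to compound 2 (0.70 log units; beyond the scatter) and the step of a 4.7-fold higher number from compound 2 to compound 3 (0.67 log units; beyond the scatter) both lie beyond the scatter, while the step of a 1.1-fold lower number from compound 1 to compound 3 (0.03 log units; within the scatter) does not. Compound 4 `Cc1cc(C#N)cc(C)c1Oc1ccnc(S(=O)(=O)CC(=O)Nc2ccc(C#N)cc2)n1` is not yet measured. Its difference from compound 2 is cyano in place of methoxy on an aromatic carbon. Going by the values given here, no measured pair exchanges two groups on the same aromatic carbon, so the nearest guidance is that the 4-methoxyphenyl compound sits apart from the other two. If the low number of compound 2 goes with the methoxy group, removing it should move compound 4 back toward compounds 1 and 3; if it goes with having a group at that place, little change is expected. Compound 4 is therefore estimated at 12000 nM in this assay, between 4000 nM and 36000 nM, a step of a 2.3-fold higher number from compound 2 to compound 4 (0.37 log units; beyond the scatter) that is expected to be modest.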

Compound 4, half-maximal cytotoxic concentration: >= 6010 nM
Compound 4: only a limit was reported; the forecaster's own chance of this, stated with the estimate: 5%; the middle value lies beyond the limit too.
By their numbers in this assay, from the lowest: compound 2; then compounds 3 and 1 (each within the scatter of the next).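

In this assay, compound 4 is reported as a limit and not as a number: the limit of >= 6010 nM in this assay, at which 1 of the 4 values shown sits.

Cyano in place of methoxy on this aromatic carbon gives an at least 1.1-fold higher number from compound 2 to compound 4 (0.07 log units; that floor lies within the scatter), so the change cannot be told apart from the usual scatter on this reading. What is new is one-sided: a group other than methoxy at this place, para to a large group, has a floor that does not fall under the number for the 4-methoxyphenyl compound, while the steps to compound 1 and to compound 3 cannot be read.

On these data alone, it stays open how far the true number of compound 4 lies over its limit, and so whether the low number of compound 2 goes with methoxy itself. An amine or a carboxylic acid at this same place could help separate those two readings.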